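Fluoro to trifluoromethoxy on the aromatic carbon

The source may report more compounds than this note shows. Statements on the series, on what has been measured and on what is new or still open speak of the compounds shown alone.

Compound 1, `COc1cccc2oc(/C=C/c3ccc(OC(F)(F)F)cc3)cc(=O)c12`, gives in a functional assay on A549 cells (Homo sapiens) for antiproliferative activity, read by MTT assay, with a stated time of 12 h (on this read-out higher numbers stand for weaker inhibition and lower numbers for stronger inhibition), only a limit of > 40000 nM.
Compound 2, `COc1cc(OC)c2c(=O)cc(/C=C/c3ccc(C(F)(F)F)cc3)oc2c1`, gives in this assay only a limit of > 40000 nM.
Compound 3, `COc1cc(OC)c2c(=O)cc(/C=C/c3ccc(F)cc3)oc2c1`, gives in this assay a number of 18600 nM.

For the measured compounds named here, compound 3 thus holds the only measured number among the three; the other two values are limits. Going by the values given here, the one measured step, an at least 2.1-fold lower number from compound 2 to compound 3 (0.33 log units; beyond the scatter), is read against (the limit of > 40000 nM in this assay, at which 2 of the 3 values shown sit), at which compound 2 sits, so its true size is unknown. Compound 4, `COc1cc(OC)c2c(=O)cc(/C=C/c3ccc(OC(F)(F)F)cc3)oc2c1`, follows from compound 3 by trifluoromethoxy in place of fluoro on an aromatic carbon. Among the compounds with values here, no measured step covers this exact exchange, but compound 1 carries the same trifluoromethoxy group on a close core, and compound 1 gives only a limit in this assay. Taken together with the step from compound 2 to compound 3, a higher number is expected for compound 4, most likely again a limit. Compound 4 is therefore estimated at 45000 nM, between 18000 nM and 120000 nM, an expected step of a 2.4-fold higher number from compound 3 to compound 4 (0.38 log units; beyond the scatter).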

Compound 4, half-maximal inhibitory concentration: 24200 nM
Estimate against measurement, compound 4: 1.9-fold (0.27 log units) above, and the stated range covers the measured number.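

In this assay, the step on the aromatic carbon para to a large group is a 1.3-fold higher number from compound 3 to compound 4 (0.11 log units; within the scatter), so the larger trifluoromethoxy group and fluoro cannot be told apart at this position on the shared core. Two further comparisons with compound 4 each change one place, trifluoromethoxy in place of trifluoromethyl giving an at least 1.6-fold lower number from compound 2 to compound 4 (0.21 log units; that floor lies within the scatter) and methoxy in place of hydrogen on the core giving an at least 1.6-fold lower number from compound 1 to compound 4 (0.21 log units; that floor lies within the scatter), so neither shows a change beyond the scatter. Both start from a limit rather than a number, which leaves their true size unknown: the limit of > 40000 nM in this assay, at which 2 of the 4 values shown sit.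

The compounds shown carry only fluorine-bearing groups at this position, so how an amine, a carboxylic acid or a longer chain would read there remains open. Also open, as far as these compounds go, is whether any group on this carbon can move the number beyond the scatter from that of compound 3.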